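Methylsulfanyl for Methoxy: Expected Cytotoxicity of Compound 4

The compounds below may be only part of what the source reports. "The series", "measured", "known", "first", "only" and "open" are said of these compounds alone.

Measured so far:
compound 1 `COc1ccnc(Nc2ccc(Cl)c(OCC=C(C)C)c2)n1` — 9000 nM
compound 2 `CC(C)=CCOc1cc(Nc2nccs2)ccc1C` — 17000 nM
compound 3 `CC(C)=CCOc1cc(Nc2ccccn2)ccc1C` — 35000 nM

In a functional assay on MT2 cells (Homo sapiens) for cytotoxicity (on this read-out lower numbers stand for higher toxicity in this test and higher numbers for lower toxicity in this test), compound 1 gives the lowest of the three numbers. The nearest is compound 2, whose gap to compound 1 lies within the scatter, so no order between these two can be claimed. Compound 3 lies further off, and its gap to compound 1 is beyond the scatter.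

Compound 4 `CSc1ccnc(Nc2ccc(Cl)c(OCC=C(C)C)c2)n1` differs from compound 1 in one place: methylsulfanyl in place of methoxy on an aromatic carbon

Within the data shown here, the only measured step, a 2.1-fold higher number from compound 2 to compound 3 (0.31 log units; beyond the scatter), concerns a different change, pyridin-2-yl in place of 1,3-thiazol-2-yl on a nitrogen on an aromatic ring, and was modest. Among the measured compounds shown here, no measured step touches the exchange of methoxy for methylsulfanyl on an aromatic carbon, so nothing in this set indicates a direction for it. Compound 4 is therefore expected to stay close to compound 1, with no change at the digits printed from compound 1 to compound 4 (within the scatter) not beyond the scatter. Compound 4 is estimated at 9000 nM, in a range from 4000 nM to 20000 nM.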

Compound 4, half-maximal cytotoxic concentration: 2800 nM
Compound 4: middle estimate off by 3.2-fold (0.51 log units), on the high side, outside the stated range (below it).
By their numbers in this assay, from the lowest: compound 4; then compounds 1 and 2 (each within the scatter of the next); then compound 3.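

In this assay, among these compounds, the exchange of methoxy for methylsulfanyl brings a 3.2-fold lower number from compound 1 to compound 4 (0.51 log units; beyond the scatter) and shows that this aromatic carbon, next to the ring nitrogen, is sensitive to the change, which the earlier compounds could not show, since their only step concerned a group on a nitrogen. The two groups have the same heavy-atom count and the same hydrogen-bond acceptor count, so a swap of sulfur for oxygen alone goes with higher toxicity in this test, by a step beyond the scatter. No measurement bears on why the number moves.

From the compounds shown here alone, whether an amine, an ethylsulfanyl group or a plain hydrogen on this carbon would move the number in the same direction remains open. The exchange appears here in a single pair, so its size on any other core is also unknown.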